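Closing a dipropylamino group into an eight-membered ring

The source may hold more compounds than are shown below. What is called first, only, known or untested is meant among the compounds shown, and "the series" means these compounds.

Compound 1, `CCCN(CCC)c1nc(C(F)(F)F)ccc1CNC(=O)C(C)c1ccc(NS(C)(=O)=O)c(F)c1`, is the reference point. In a functional assay on CHO-K1 cells for antagonist activity at transient receptor potential cation channel subfamily V member 1 (Homo sapiens), read by FLIPR (on this read-out higher numbers stand for weaker inhibition and lower numbers for stronger inhibition), compound 1 gives 0.2 nM, the lowest of the three numbers available. Compound 3, `CC(C(=O)NCc1ccc(C(F)(F)F)nc1N1CCC(OC(=O)C(C)(C)C)CC1)c1ccc(NS(C)(=O)=O)c(F)c1`, gives 2 nM in this assay, and compound 2, `C[C@H](C(=O)NCc1ccc(C(F)(F)F)nc1N1CC[C@@H](N(C)C)C1)c1ccc(NS(C)(=O)=O)c(F)c1`, gives 101 nM; both of these gaps to compound 1 lie beyond the usual scatter, so compound 1 is the strongest inhibitor among the measured set.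

The new compound is compound 4, `CC(C(=O)NCc1ccc(C(F)(F)F)nc1N1CCCCCCC1)c1ccc(NS(C)(=O)=O)c(F)c1`. It differs from compound 1 in one place: a group of 8 heavy atoms (7 carbon, 1 nitrogen; one eight-membered non-aromatic ring with 1 hetero atom) in place of a group of 7 heavy atoms (6 carbon, 1 nitrogen; no ring), on an aromatic carbon. The two amino groups that make the change are of nearly the same size and carry the same count of donors and acceptors, the main difference being that the open chains of compound 1 are tied together into a ring in compound 4.

Among the measured compounds shown here, no measured pair shows this exact change, so the expectation rests on the closeness of the two groups. A small step, if any, is expected for compound 4, and a 2.5-fold higher number from compound 1 to compound 4 (0.40 log units; beyond the scatter) describes the expected shift toward a slightly higher number. Compound 4 is therefore estimated at 0.5 nM in this assay, with a likely range from 0.1 nM to 3 nM.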

Compound 4, inhibition constant: 0.7 nM
Estimate against measurement, compound 4: 1.4-fold (0.15 log units) below, within the range that was stated.
By their numbers in this assay, from the lowest: compound 1; then compound 4; then compound 3; then compound 2.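

Among the compounds shown here, this step gives the first single-change reading at this position, an aromatic carbon next to the ring nitrogen: tying the open chains of dipropylamino into an eight-membered ring gives a 3.5-fold higher number from compound 1 to compound 4 (0.54 log units; beyond the scatter) in this assay. The open chains are therefore not required for strong inhibition, as compound 4 still gives 0.7 nM even though the change carries a modest cost that lies beyond the usual scatter. Nothing measured here accounts for this shift.

Still open, as far as these compounds go, is how other cyclic amines, such as azepane or plain piperidine, would compare with the eight-membered ring at this carbon. Open chains such as diethylamino or dibutylamino would likewise show how much the length of the chains matters relative to dipropylamino.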